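The source may hold more compounds than are shown below. What is called first, only, known or untested is meant among the compounds shown, and "the series" means these compounds.

In a physicochemical assay for solubility, in phosphate buffer (on this read-out higher numbers stand for higher solubility and lower numbers for lower solubility), compound 1 (`C/C=C/C(=O)c1ccc(CCCCCCC)cc1`) reads 41000 nM and compound 2 (`C=C(C)C(=O)c1ccc(CCCCCCC)cc1`) reads 37000 nM and compound 3 (`C/C=C/C(=O)Nc1ccc(CCCCCC)cc1`) reads 42000 nM with all three within the usual scatter of one another. Compound 4 (`CCCCCCc1ccc(NC(=O)C=C(C)C)cc1`) is still unmeasured and differs from compound 3 by 2-methylprop-1-en-1-yl in place of prop-1-en-1-yl on a carbonyl carbon with 2-methylprop-1-en-1-yl in place of prop-1-en-1-yl on a carbonyl carbon. Among the compounds with values here, no measured pair shows this exact change. The nearest is a 1.1-fold lower number from compound 1 to compound 2 (0.04 log units; within the scatter) where 1-methylethenyl replaces prop-1-en-1-yl on a carbonyl carbon, and it stays within the scatter. No change beyond the scatter is therefore expected in this assay and the estimated step is a 1.1-fold lower number from compound 3 to compound 4 (0.04 log units; within the scatter) as a small one. For compound 4 the expected value is 38000 nM (20000 nM to 55000 nM).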

Compound 4, solubility: 37000 nM
The estimate for compound 4 lay 1.0-fold (0.01 log units) above the measured number, and the stated range covers the measured number.
By their numbers in this assay, from the lowest: compounds 2, 4, 1 and 3 (each within the scatter of the next).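

In this assay, placing 2-methylprop-1-en-1-yl in place of prop-1-en-1-yl on a carbonyl carbon whose other neighbour is an amide-type nitrogen gives a 1.1-fold lower number from compound 3 to compound 4 (0.06 log units; within the scatter), so this step stays within the scatter. Compounds 1 and 2 showed a swap at a carbonyl carbon only without that nitrogen, and with a different entering group. Nothing available explains the size of this step. Both swaps exchange one carbon-only group with a double bond for another, so an amine or a carboxylic acid on this carbonyl carbon remains an open case.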